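From 3-phenylpropyl to 2-phenylcyclopropyl on the amide nitrogen

A few compounds are considered here, and "the series" means these few. Any claim that something is new, unique, unknown or untested is made for them only; others in the source may bear on it.

In an ADME assay on a cell-free system (plasma, Mus musculus) for metabolic stability, tested at 1 uM (on this read-out lower numbers stand for a shorter-lived compound and higher numbers for a longer-lived compound), compound 1 `C=CC(=O)N[C@@H]1CCCN(S(=O)(=O)c2ccc(NC(=O)OCc3ccccc3)cc2)C1` gives > 6 h as a limit and not as a number. Compound 2 `C=CC(=O)NC1CCN(S(=O)(=O)c2ccc(C(=O)NCc3ccccc3)cc2)CC1` likewise gives > 6 h as a limit. Compound 3 `C=CC(=O)NC1CCN(S(=O)(=O)c2ccc(C(=O)NCCCc3ccccc3)cc2)CC1` also stands only at a limit, > 6 h and no number is known for it. The three compounds therefore share one reading, the limit of > 6 h in this assay, at which 3 of the 3 values shown sit, and this leaves no order among them.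

Compound 4 `C=CC(=O)NC1CCN(S(=O)(=O)c2ccc(C(=O)N[C@@H]3C[C@H]3c3ccccc3)cc2)CC1` carries 2-phenylcyclopropyl in place of 3-phenylpropyl on an amide-type nitrogen. One measured change bears on this place, a step that the two limits leave unreadable from compound 2 to compound 3 and it offers no size to carry over. On that basis, the expected change is a step that the limit leaves unreadable from compound 3 to compound 4 with no shift in either direction foreseen beyond the scatter. Compound 4 is expected to report a limit as well. For compound 4 the estimate is 7 h within an expected range from 4 h to 12 h in this assay terms.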

Compound 4, half-life: > 6 h
Compound 4: only a limit was reported; the forecaster's own chance of this, stated with the estimate: 80%; the middle value does not contradict the limit.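

In this assay compound 4 gives > 6 h, a limit and not a number. The steps to compound 4 from compound 2 and compound 3 therefore cannot be read. The compounds shown leave open the actual half-lives of compounds 1 to 4 and any order among them, as all share one reading: the limit of > 6 h in this assay, at which 4 of the 4 values shown sit.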